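The source may report more compounds than this note shows. Statements on the series, on what has been measured and on what is new or still open speak of the compounds shown alone.

Working notes on the series. In a functional assay on A-375 cells (Homo sapiens) for antiproliferative activity, read by MTT assay, with a stated time of 24 h (a higher number here means a weaker inhibitor, a lower number a stronger inhibitor), compound 1 `COc1cc(OC)c(-c2coc3cc(OCc4ccccc4C(F)(F)F)ccc3c2=O)cc1OC` reads > 10000 nM, which is a limit of the assay and not a number. Among the measured compounds shown here, compound 2 `COc1cc(OC)c(-c2coc3cc(OCc4cccc(Br)c4)ccc3c2=O)cc1OC` gives 1120 nM, the only true number so far, so its standing rests on a single comparison with compound 1.

The next compound is compound 3 `COc1cc(OC)c(-c2coc3cc(OCc4cccc(C(F)(F)F)c4)ccc3c2=O)cc1OC`. The change is trifluoromethyl in place of bromo on an aromatic carbon, meta to a large group, turning 3-bromobenzyl into 3-(trifluoromethyl)benzyl.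

For the measured compounds named here, only one measured step bears on this, an at least 8.9-fold lower number from compound 1 to compound 2 (0.95 log units; beyond the scatter). Going by the values given here, that step alters the group and its position together, so it gives only a loose guide, and no step has yet changed the group alone. Compound 3 keeps the position of the bromo in compound 2 but carries the group found in compound 1, so an at least 8.9-fold lower number from compound 1 to compound 2 (0.95 log units; beyond the scatter) supports only a slight lean towards a higher number in this assay, with no shift beyond the scatter expected. The expected change is a 1.6-fold higher number from compound 2 to compound 3 (0.21 log units; within the scatter). For compound 3 the estimated value is 1800 nM, with an expected range of 600 nM to 6000 nM.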

Compound 3, half-maximal inhibitory concentration: 1140 nM
Compound 3: the middle estimate sits 1.6-fold (0.20 log units) above what was measured; measured number inside the range.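

In this assay, with the position held, trifluoromethyl in place of bromo gives two compounds that cannot be told apart, a 1.0-fold higher number from compound 2 to compound 3 (0.01 log units; within the scatter), so among the compounds shown, 3-bromobenzyl and 3-(trifluoromethyl)benzyl read alike. The series now also has a step that changes the position alone with the group held, 3-(trifluoromethyl)phenyl in place of 2-(trifluoromethyl)phenyl, an at least 8.7-fold lower number from compound 1 to compound 3 (0.94 log units; beyond the scatter), and its size matches that of the earlier step in which group and position changed together, which places the difference among these three compounds on the position rather than on the group. Compound 1 reads > 10000 nM, which is a limit of the assay and not a number, so both steps from it give only a lower bound on size: the limit of > 10000 nM in this assay, at which 1 of the 3 values shown sits.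

Still open, from the compounds shown here alone, is whether the agreement between bromo and trifluoromethyl extends to an amine or a carboxylic acid on the same aromatic carbon. Also open, going by these compounds, is whether bromo on the position that trifluoromethyl occupies in compound 1 would reach the same limit, which would show whether the position effect holds beyond a single group.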